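From a Dibenzyl Ester to a Hydroxyl Side Chain

The compounds below may be only part of what the source reports. "The series", "measured", "known", "first", "only" and "open" are said of these compounds alone.

compound 1: `O=C(CN(c1ncnc2c1ncn2C1CCCCO1)C1CC1)N[C@@H](CCC(=O)OCc1ccccc1)C(=O)OCc1ccccc1` — 34.7%
compound 2: `N=C(N)NCCC[C@H](NC(=O)CN(c1nc(Cl)nc2[nH]cnc12)C1CC1)C(=O)OCc1ccccc1` — 30.6%
compound 3: `NCCCC[C@H](NC(=O)CN(c1nc(Cl)nc2[nH]cnc12)C1CC1)C(=O)OCc1ccccc1` — 41.2%

Three compounds were measured in a functional assay on the whole organism (Tail, strain ICR) with Mus musculus as the target, in the tail flick test, with a stated time of 60 min, at a dose of 25 umol/kg by the oral route; on this read-out higher numbers stand for a stronger effect at the one dose given and lower numbers for a weaker effect. Compound 1 sits between the other two on these numbers, and both gaps, to compound 2 and to compound 3, lie within the usual scatter, so nothing separates the three with confidence.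

Compound 4, `O=C(CN(c1ncnc2c1ncn2C1CCCCO1)C1CC1)N[C@@H](CO)C(=O)OCc1ccccc1`, is not yet measured. It differs from compound 1 by hydroxy in place of (benzyloxycarbonyl)methyl on a saturated chain carbon, two bonds along the chain from an amide-type nitrogen and a carbonyl carbon.

Within the data shown here, only one step between measured compounds is on record: a number 10.6 percentage points higher from compound 2 to compound 3 (beyond the scatter). That step sits at a different place on the chain, four bonds along, on a core that carries a chlorine and no tetrahydropyranyl group, and it exchanges one nitrogen-containing group for another. Among the measured compounds shown here, it does not touch the position changed between compound 1 and compound 4, and no measured pair trades an ester-bearing side chain for a hydroxy group. For the measured compounds named here, there is therefore no step that bears directly on the change at hand.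

With nothing pointing either way, the step is expected to stay within the scatter, a number 0.3 percentage points higher from compound 1 to compound 4 (within the scatter). Compound 4 is estimated at 35%, in a range from 20% to 50%.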

Compound 4, a percentage reported as activity, at one dose (the size of the read-out at that dose, not a potency): 46.7%
The estimate for compound 4 lay 11.7 percentage points below the measured number; low and high end bracket the measured number.
By their numbers in this assay, from the lowest: compounds 2, 1, 3 and 4 (each within the scatter of the next, the first and the last beyond it).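

In this assay, among these compounds, the exchange of (benzyloxycarbonyl)methyl for hydroxy gives a number 12 percentage points higher from compound 1 to compound 4 (beyond the scatter), the first step on record at this place, on a saturated chain carbon, two bonds along the chain from an amide-type nitrogen and a carbonyl carbon. Among the compounds shown here, the only earlier step lay four bonds along, on a different core, so this result adds that what this carbon carries can move the read-out beyond the scatter, and that the six-membered aromatic ring and ester of the leaving group are not required for the effect at this one dose. The measurements on hand offer nothing that accounts for the step.

The change removes the ring, the ester and most of the group's heavy atoms while bringing in a hydrogen-bond donor, all at once, so the compounds shown cannot say which of these differences matters. On these data alone, whether a methoxy group, an amine or a carboxylic acid on this carbon would read like hydroxy or like (benzyloxycarbonyl)methyl remains open, as does what the hydroxy group does on the chlorine-bearing core.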